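Removing a fluorine from compound 1: how stable will compound 4 be?

The source may report more compounds than this note shows. Statements on the series, on what has been measured and on what is new or still open speak of the compounds shown alone.

Of the compounds shown here, three that share one core have been measured in an ADME assay on microsomes from liver (Homo sapiens) for metabolic stability, using NADPH, with a stated time of 40 min, tested at 2 uM; on this read-out lower numbers stand for a shorter-lived compound and higher numbers for a longer-lived compound. Compound 1 `Cc1cccc2c(-c3ccc4ccc(F)cc4n3)c[nH]c12` gives 0.883 h in this assay, the second highest of the three numbers. Compound 3 `Fc1cc2c(-c3ccc4c(C(F)(F)F)cccc4n3)c[nH]c2c(F)c1F` gives 1.12 h, a number that lies within the usual scatter of the result for compound 1, so the two cannot be told apart. Compound 2 `Fc1cc(Cl)c2[nH]cc(-c3ccc4ccccc4n3)c2c1` gives 0.383 h, which lies beyond the scatter below compound 1.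

Compound 4 `Cc1cccc2c(-c3ccc4ccccc4n3)c[nH]c12` is compound 1 with one change: hydrogen in place of fluoro on an aromatic carbon. Within the data shown here, no pair of measured compounds differs in only this way, so the size of this step is not known from a direct comparison. What can be said is that compound 2, whose quinoline-type half carries no fluorine, has the lowest number of the three, while compounds 1 and 3, each carrying a fluorine or a trifluoromethyl on that half, sit higher. This is a loose hint from three compounds only, and the other differences between them leave it uncertain.

On that basis compound 4 is expected to give a somewhat shorter half-life than compound 1, a step of a 1.5-fold lower number from compound 1 to compound 4 (0.17 log units; within the scatter), most likely within the scatter but possibly a little beyond. The estimate for compound 4 in this assay is 0.6 h, with a range from 0.3 h to 1.2 h.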

Compound 4, half-life: 0.35 h
Compound 4: middle estimate off by 1.7-fold (0.23 log units), on the high side; low and high end bracket the measured number.
By their numbers in this assay, from the lowest: compounds 4 and 2 (each within the scatter of the next); then compounds 1 and 3 (each within the scatter of the next).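

Hydrogen in place of fluoro on this aromatic carbon gives a 2.5-fold lower number from compound 1 to compound 4 (0.40 log units; beyond the scatter) in this assay, the first direct reading of this one change among the compounds shown. Before this pair, any link between fluorine and half-life rested on compounds that differed in several places at once, whereas here the two structures differ only at the carbon that is meta to a fused ring and para to a fused ring. A single fluorine at this position is therefore enough to move the half-life beyond the usual scatter, although nothing measured here shows why the number moves in this direction.

The compounds shown leave open whether another group on this same carbon, such as chloro, methoxy, a nitrile or an amine, would give a half-life like that of the fluoro compound or one further away. Going by these compounds, it also remains open whether the step would keep its size with a group other than the methyl elsewhere in the molecule, as this reading rests on one pair.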